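Lengthening an Ester Chain and Cytotoxicity on Lung Cells

The compounds below may be only part of what the source reports. "The series", "measured", "known", "first", "only" and "open" are said of these compounds alone.

Three compounds sharing one core have been tested in a functional assay on A549 cells (Homo sapiens) for cytotoxicity, read by MTT assay, with a stated time of 24 h, tested at 40 uM; on this read-out higher numbers stand for a weaker effect at the one concentration tested and lower numbers for a stronger effect:

Compound 1, `CCCCCCCCCCOC(=O)CCC(=O)N1CCN(CCCOc2cc3c(Nc4ccc(F)c(Cl)c4)ncnc3cc2OC)CC1`: 15.5%
Compound 2, `CCCCCCCCCCCOC(=O)CCC(=O)N1CCN(CCCOc2cc3c(Nc4ccc(F)c(Cl)c4)ncnc3cc2OC)CC1`: 12%
Compound 3, `CCCCCCCCCCCCCCCOC(=O)CCC(=O)N1CCN(CCCOc2cc3c(Nc4ccc(F)c(Cl)c4)ncnc3cc2OC)CC1`: 85.5%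

Compound 2 differs from compound 1 by methyl in place of hydrogen on a saturated chain carbon, ten or more bonds along the chain from an oxygen next to a carbonyl group, and this gives a number 3.5 percentage points lower from compound 1 to compound 2 (within the scatter). Compound 3 differs from compound 1 by pentyl in place of hydrogen on a saturated chain carbon, ten or more bonds along the chain from an oxygen next to a carbonyl group, a much larger extension of the same chain, and here the read-out moves by a number 70 percentage points higher from compound 1 to compound 3 (beyond the scatter). Compound 4, `CCCCCCCCCCCCCCCCOC(=O)CCC(=O)N1CCN(CCCOc2cc3c(Nc4ccc(F)c(Cl)c4)ncnc3cc2OC)CC1`, has not yet been tested; it differs from compound 3 by methyl in place of hydrogen on a saturated chain carbon, ten or more bonds along the chain from an oxygen next to a carbonyl group, the same change at the same place as from compound 1 to compound 2. Since that earlier single-carbon change gave only a number 3.5 percentage points lower from compound 1 to compound 2 (within the scatter), the step from compound 3 to compound 4 is expected to be small, about a number 0.5 percentage points higher from compound 3 to compound 4 (within the scatter). In this assay compound 4 is therefore estimated at 86%, with a likely range from 68% to 100%.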

Compound 4, a percentage reported as activity, at one concentration (the size of the read-out at that concentration, not a potency): 82.6%
Beside the measured number, compound 4's estimate is 3.4 percentage points above it, within the range that was stated.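

In this assay the one-methyl step gives a number 2.9 percentage points lower from compound 3 to compound 4 (within the scatter), and this agrees with the same step on the shorter chain: the same change on two cores in this assay, a number 3.5 percentage points lower (within the scatter) from compound 1 to compound 2 and a number 2.9 percentage points lower (within the scatter) from compound 3 to compound 4, 0.6 percentage points apart, within the scatter of two such steps. The larger lengthening also carries over, with a number 70.6 percentage points higher from compound 2 to compound 4 (beyond the scatter), matching the earlier step: the same change on two cores in this assay, a number 70 percentage points higher (beyond the scatter) from compound 1 to compound 3 and a number 70.6 percentage points higher (beyond the scatter) from compound 2 to compound 4, 0.6 percentage points apart, within the scatter of two such steps. Going by these compounds alone, the widest comparison gives a number 67.1 percentage points higher from compound 1 to compound 4 (beyond the scatter), but these agreements rest on only two pairs for each change and show neither where along the chain the large shift begins nor whether the same steps would hold on a different core.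

Chains of intermediate length between those of compound 2 and compound 3 remain open. So do a longer chain than that of compound 4 and a benzyl group in place of the chain.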